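The source may report more compounds than this note shows. Statements on the series, on what has been measured and on what is new or still open speak of the compounds shown alone.

Working notes on the series, with every number read in a functional assay on the whole organism with Scenedesmus acutus as the target; on this read-out higher numbers stand for weaker inhibition and lower numbers for stronger inhibition. Compound 1 `CCOC(=O)c1cc(N2C(=O)C3=C(CCCC3)C2=O)c(F)cc1Cl` gives 100 nM, and compound 2 `CC(C)OC(=O)c1cc(N2C(=O)C3=C(CCCC3)C2=O)c(F)cc1Cl` gives 57.5 nM. Among the compounds with values here, these are the only two numbers so far, and they lie within the scatter of each other, so compound 2 cannot be ranked against compound 1.

Compound 3 `CCCCOC(=O)c1cc(N2C(=O)C3=C(CCCC3)C2=O)c(F)cc1Cl` keeps the shared core and changes only the group on the ester oxygen: butyl in place of isopropyl on an oxygen next to a carbonyl group, (butyl in place of isopropyl on an oxygen next to a carbonyl group). The isopropoxycarbonyl to butoxycarbonyl change has not been measured on any other pair. Within the data shown here, one measured step bears on it, since it too alters the chain on that oxygen: a 1.7-fold lower number from compound 1 to compound 2 (0.24 log units; within the scatter), which stays within the scatter. Among the measured compounds shown here, that single step is thin evidence, and no measured compound carries a butyl group. Even so, no step beyond the scatter is expected in this assay, and no direction can be argued. The estimate amounts to a 1.1-fold higher number from compound 2 to compound 3 (0.05 log units; within the scatter), an expected step within the scatter. For compound 3 the expected value is 65 nM, with an estimated range of 25 nM to 170 nM.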

Compound 3, half-maximal inhibitory concentration: 67.6 nM
Compound 3: middle estimate off by 1.0-fold (0.02 log units), on the low side, and the stated range covers the measured number.
By their numbers in this assay, from the lowest: compounds 2, 3 and 1 (each within the scatter of the next).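

In this assay, butyl in place of isopropyl on an oxygen next to a carbonyl group gives a 1.2-fold higher number from compound 2 to compound 3 (0.07 log units; within the scatter), and the same oxygen with butyl against ethyl gives a 1.5-fold lower number from compound 1 to compound 3 (0.17 log units; within the scatter), so an unbranched chain beyond ethyl now joins the isopropyl group without any step beyond the scatter. Within the data shown here, with all three steps among compounds 1, 2 and 3 printed as within the scatter, the ethyl, isopropyl and butyl groups cannot be ordered, and this position so far accepts all three with the shared core held constant. Nothing on hand offers an explanation for how small these steps are.

Still open, going by these compounds, is whether a step beyond the scatter appears with a much longer chain such as octyl, with a ring such as cyclohexyl on this oxygen, or with a carboxylic acid in place of the ester. The three compounds also differ only in this one place, so they say nothing about how changes elsewhere on the shared core would read, or whether the same tolerance would hold there.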